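Working notes: the step from compound 3 to compound 4

The source may report more compounds than this note shows. Statements on the series, on what has been measured and on what is new or still open speak of the compounds shown alone.

For the measured compounds named here, in a functional assay on MCF7 cells (Homo sapiens) for antiproliferative activity, read by MTT assay, with a stated time of 24 h (a lower number here means a stronger inhibitor, a higher number a weaker inhibitor), compound 3 `CCN(CC)CCNC(=O)C1CC=C(C(CC)(CC)c2ccc(C#CC(C)(O)CC)c(C)c2)N1CC` gives 600 nM as the lowest of the three numbers so far. In this assay, going by the values given here, compound 1 `CCN(CC)CCNC(=O)C1CC(C(CC)(CC)c2ccc(C#CC(O)C3CCC3)c(C)c2)=CN1CC` gives 1280 nM and compound 2 `CCN(CC)CCNC(=O)C1CC(C(CC)(CC)c2ccc(C#CC(O)C3CCCCC3)c(C)c2)=CN1CC` gives 3070 nM on a core that differs from the one shared by compound 3 and compound 4 `CCN(CC)CCNC(=O)C1CC=C(C(CC)(CC)c2ccc(C#CC(O)C3CCCC3)c(C)c2)N1CC`. The change to follow is cyclopentyl(hydroxy)methyl in place of 1-hydroxy-1-methylpropyl on a triple-bonded carbon with the core of compound 3 kept.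

Among the compounds with values here, no measured step tests this change directly. The nearest evidence is a 2.4-fold higher number from compound 1 to compound 2 (0.38 log units; beyond the scatter) which is a modest step on swapping cyclobutyl for cyclohexyl. Cyclopentyl is a ring size inside that measured range, so the ring-bearing alcohol groups offer the only guide, though on the other core. Both read higher than compound 3, with compound 1 the closer at 1280 nM. A modest move to a higher number is therefore expected, and the estimated size is a 2.5-fold higher number from compound 3 to compound 4 (0.40 log units; beyond the scatter). For compound 4 the expected value is 1500 nM with an estimated range of 700 nM to 3200 nM.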

Compound 4, half-maximal inhibitory concentration: 1580 nM
Compound 4: middle estimate off by 1.1-fold (0.02 log units), on the low side; low and high end bracket the measured number.
By their numbers in this assay, from the lowest: compound 3; then compounds 1, 4 and 2 (each within the scatter of the next, the first and the last beyond it).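

In this assay, for the compounds shown here, the only step on the core of compound 3 is a 2.6-fold higher number from compound 3 to compound 4 (0.42 log units; beyond the scatter), so the number at this place on a triple-bonded carbon also moves on this core, and not only on the other core, where the ring swap gives a 2.4-fold higher number from compound 1 to compound 2 (0.38 log units; beyond the scatter). The step replaces an open chain of 5 heavy atoms with a five-membered carbon ring group of 7 heavy atoms, while the counts of hydrogen-bond donors and acceptors and the absence of net charge stay the same. No measured evidence accounts for the higher number.

The step changes ring, size and the substitution of the hydroxyl-bearing carbon together, so these cannot be separated. An amine in place of the hydroxyl, or a longer open chain, remains untested among the compounds shown here.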